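The compounds below may be only part of what the source reports. "The series", "measured", "known", "first", "only" and "open" are said of these compounds alone.

Working notes on the series. Compound 2 `COc1cc(-c2ccnc3cc(-c4ccc(Cl)cc4)nn23)cc(OC)c1OC` carries a 4-chlorophenyl on the shared core; in a functional assay on A549 cells (Homo sapiens) for inhibition, read by CCK-8 assay, with a stated time of 48 h (on this read-out higher numbers stand for weaker inhibition and lower numbers for stronger inhibition), compound 2 gives 3070 nM, the highest of the two plain numbers in the set. Compound 1 `COc1ccc(-c2cc3nccc(-c4cc(OC)c(OC)c(OC)c4)n3n2)cc1N` carries a 3-amino-4-methoxyphenyl at the same place and in this assay gives 138 nM; the step of a 22-fold higher number from compound 1 to compound 2 (1.35 log units; beyond the scatter) is large. Compound 3 `COc1cc(-c2ccnc3cc(-c4ccc(C(C)(C)C)cc4)nn23)cc(OC)c1OC` carries a 4-(tert-butyl)phenyl. In this assay compound 3 reports only a limit, > 10000 nM (the limit of > 10000 nM in this assay, at which 1 of the 3 values shown sits). The steps of an at least 72-fold higher number from compound 1 to compound 3 (1.86 log units; beyond the scatter) and an at least 3.2-fold higher number from compound 2 to compound 3 (0.51 log units; beyond the scatter) both run toward weaker inhibition.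

Compound 4 `COc1ccc(-c2cc3nccc(-c4cc(OC)c(OC)c(OC)c4)n3n2)cc1F` is not yet measured. The change from compound 2: 3-fluoro-4-methoxyphenyl in place of 4-chlorophenyl on an aromatic carbon. The entering group keeps the methoxy of compound 1 and carries fluorine where compound 1 carries an amino group. The step bearing most directly on this change is a 22-fold higher number from compound 1 to compound 2 (1.35 log units; beyond the scatter), read in reverse; the step of an at least 3.2-fold higher number from compound 2 to compound 3 (0.51 log units; beyond the scatter) concerns a different exchange and bears on it only loosely. A large move back toward compound 1 is therefore expected, though with fluorine in place of amino the full return is uncertain. Compound 4 is estimated at 500 nM in this assay, within 150 nM to 2000 nM. The step of a 6.1-fold lower number from compound 2 to compound 4 (0.79 log units; beyond the scatter) is expected to lie beyond the scatter.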

Compound 4, half-maximal inhibitory concentration: 545 nM
Compound 4: the middle estimate sits 1.1-fold (0.04 log units) below what was measured, and the stated range covers the measured number.
By their numbers in this assay, from the lowest: compound 1; then compound 4; then compound 2. At a limit, above all of these: compound 3.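

In this assay, with the methoxy kept and only fluoro in place of amino on an aromatic carbon, the piece shows a 3.9-fold higher number from compound 1 to compound 4 (0.60 log units; beyond the scatter): the amino group of compound 1 accounts for part of the distance to compound 2, but not all of it. The exchange of 4-chlorophenyl for 3-fluoro-4-methoxyphenyl gives a 5.6-fold lower number from compound 2 to compound 4 (0.75 log units; beyond the scatter), a gain beyond the scatter with no amino group present, and both groups count 0 hydrogen-bond donors, which means that in this pair the lower number does not depend on a donor on the aromatic ring. Compound 3 stands only at a limit, and an at least 18-fold lower number from compound 3 to compound 4 (1.26 log units; beyond the scatter) is a bound and not a measured distance: the limit of > 10000 nM in this assay, at which 1 of the 4 values shown sits.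

The compounds shown leave open how much of the gain from compound 2 to compound 4 belongs to the methoxy and how much to the fluoro, as no compound here separates the two. Also open, on these data alone, is whether a hydroxyl or a methylamino group in the place of the amino would match compound 1, which gives 138 nM.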